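This account rests on a few compounds, and the source may have more. Where it says the series, first, only, none or still open, it means among the compounds named here.

Of the compounds shown here, two with a shared core have been measured so far in a functional assay on L1210 cells (Mus musculus) for inhibition; a lower number here means a stronger inhibitor, a higher number a weaker inhibitor. Compound 1 `O=C1CCCCC/C1=C\c1cccc(Cl)c1`, which carries chloro, gives 144000 nM, and compound 2 `O=C1CCCCC/C1=C\c1cccc(Br)c1`, which carries bromo, gives 246000 nM. Within the data shown here, the one measured step, a 1.7-fold higher number from compound 1 to compound 2 (0.23 log units; within the scatter), lies within the scatter, so compound 2 stands level with compound 1 and the two cannot be ranked.

The next compound is compound 3 `O=C1CCCCC/C1=C\c1cccc([N+](=O)[O-])c1`, not yet measured, with nitro in place of bromo on an aromatic carbon. Among the measured compounds shown here, the step of a 1.7-fold higher number from compound 1 to compound 2 (0.23 log units; within the scatter) is the only guide available, and it is a loose one. For the measured compounds named here, it exchanged one halogen for another, whereas nitro is a different kind of group, and no compound with nitro has a measured value yet. No step beyond the scatter is therefore expected, and the data favour no clear direction. The expected change is a 1.2-fold lower number from compound 2 to compound 3 (0.09 log units; within the scatter). Going by the values given here, only two measurements support this expectation, so the range is kept wide. For compound 3 the estimated value is 200000 nM, with an expected range from 70000 nM to 550000 nM.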

Compound 3, half-maximal inhibitory concentration: 162000 nM
Compound 3: the middle estimate sits 1.2-fold (0.09 log units) above what was measured; the range from low to high includes it.
By their numbers in this assay, from the lowest: compounds 1, 3 and 2 (each within the scatter of the next).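

Swapping bromo for nitro on the aromatic carbon does not separate the two compounds in this assay (a 1.5-fold lower number from compound 2 to compound 3 (0.18 log units; within the scatter)), and the same holds for swapping chloro for nitro (a 1.1-fold higher number from compound 1 to compound 3 (0.05 log units; within the scatter)). The earlier step only exchanged one halogen for another, whereas this one brings in a group of a different kind, with more heavy atoms and with hydrogen-bond acceptors that bromo lacks, and the number still stays within the scatter. Chloro, bromo and nitro therefore cannot be ranked at this place on the ring, and nothing available explains why the three read alike.

Going by these compounds, what stays open is whether any group at this place can move the number beyond the scatter, and an amine, a carboxylic acid or a longer chain such as a butyl group would each put that to a sharper test. On these data alone, all three compounds also share the same core, so it remains unknown how much a change elsewhere in that core would matter, with chloro, bromo or nitro held fixed on the aromatic ring.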